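The source may hold more compounds than are shown below. What is called first, only, known or untested is meant among the compounds shown, and "the series" means these compounds.

Measured so far:
compound 1, `CC1CCCCC1C(=O)N1CC(c2nc(-c3cccc(F)c3)no2)C1`, gives 540 nM in an assay on HEK293 cells for positive allosteric modulation of metabotropic glutamate receptor 5 (Homo sapiens), read by FLIPR; a higher number here means that more compound is needed for the effect, a lower number that less compound is needed
compound 2, `CC1CCCC(C(=O)N2CC(c3nc(-c4cccc(Cl)c4)no3)C2)C1`, gives 410 nM in this assay

Compound 2 gives the lower of the two numbers, but its distance to compound 1 lies within the usual scatter, so the two cannot be told apart on these data. Compound 3, `CC1CCC(C(=O)N2CC(c3nc(-c4cccc(Cl)c4)no3)C2)CC1`, is built from the same atoms as compound 2, joined differently: 4-methylcyclohexyl in place of 3-methylcyclohexyl on a carbonyl carbon. The methyl group on the saturated ring simply moves to another carbon of that ring, and everything else stays as it was. Among the compounds with values here, no pair of measured compounds shows a change of this kind, so there is no measured step to lean on. Moving a methyl group around a saturated ring of this sort is expected to leave the number close to where it was, with no direction favoured. Compound 3 is therefore expected to give about 500 nM, between 180 nM and 1500 nM, meaning an expected step of a 1.2-fold higher number from compound 2 to compound 3 (0.09 log units; within the scatter) that stays within the scatter.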

Compound 3, half-maximal effective concentration: 1500 nM
The estimate for compound 3 lay 3.0-fold (0.48 log units) below the measured number; the measured number falls inside the stated range.
By their numbers in this assay, from the lowest: compounds 2 and 1 (each within the scatter of the next); then compound 3.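

Where the methyl group sits on the saturated ring matters in this assay: the change to 4-methylcyclohexyl brings a 3.7-fold higher number from compound 2 to compound 3 (0.56 log units; beyond the scatter), so more compound is needed for the same effect. The group that leaves and the group that enters have the same heavy atoms and the same counts of hydrogen-bond donors and acceptors, so those counts alone do not predict the result at this place on the carbonyl carbon. Nothing available here explains why this move changes the number.

Compound 1 differs from compound 2 in two places, so it cannot show what 2-methylcyclohexyl would do alongside the same chlorophenyl group. Also open, as far as these compounds go, is whether plain cyclohexyl, with no methyl at all, would sit nearer compound 2 or compound 3, and whether a hydroxyl group or an ethyl group would be tolerated on that ring.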